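Lengthening the Alkyl Chain from Compound 1 to Compound 4

A few compounds are considered here, and "the series" means these few. Any claim that something is new, unique, unknown or untested is made for them only; others in the source may bear on it.

Of the compounds shown here, three have been measured in a physicochemical assay for lipophilicity; on this read-out higher numbers stand for higher lipophilicity and lower numbers for lower lipophilicity. Compound 1 `CCCCCCCCCCCCNCCN` gives 4.69 in this assay. Compound 2 `CCCCCCCCNCCO` gives 2.55, and compound 3 `CCCCCCCCCCNCCCN` gives 2.82. Compound 1 therefore stands highest of the three numbers; its nearest neighbour is compound 3, which lies lower by more than the usual scatter, and compound 2 lies lower still, also beyond the scatter. No pair among these three differs in a single place, so no single-change step can be read from the measured set.

Compound 4 `CCCCCCCCCCCCCCNCCN` has not yet been measured in this assay. It differs from compound 1 by ethyl in place of hydrogen on a saturated chain carbon, ten or more bonds along the chain from an amine nitrogen; cut one bond further out, the same difference reads methyl to propyl, ethyl to butyl, propyl to pentyl. For the measured compounds named here, nothing among the measured compounds isolates this change, so the expected step rests on the structural change alone and on the value of compound 1, which gives 4.69. The step is expected to be an increase, a number 1.01 log units higher from compound 1 to compound 4 (beyond the scatter), clearly beyond the scatter. On that basis compound 4 is estimated to give 5.7 in this assay, with a range from 5.1 to 6.3.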

Compound 4, partition coefficient: 4.5
The estimate for compound 4 lay 1.20 log units above the measured number; the measured number lies below the stated range.
By their numbers in this assay, from the lowest: compounds 2 and 3 (each within the scatter of the next); then compounds 4 and 1 (each within the scatter of the next).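

In this assay the series now holds its first single-change step: ethyl in place of hydrogen on a saturated chain carbon, ten or more bonds along the chain from an amine nitrogen, reads a number 0.19 log units lower from compound 1 to compound 4 (within the scatter). For the compounds shown here, the read-out therefore does not separate this pair, and at this position on the core of compound 1 the added ethyl leaves no step that can be told from repeat scatter, something the earlier compounds, none of which differed in a single place, could not show. No measurement at hand bears on what lies behind this result.

As far as these compounds go, a single step fixes no trend, so it remains open whether a longer chain at this same place would also stay within the scatter of compound 1, or whether a shorter chain would do so. Also open, from the compounds shown here alone, is how the number would respond if a polar group, such as a hydroxyl or a carboxylic acid, stood at this place on the saturated chain carbon instead of ethyl.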